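A few compounds are considered here, and "the series" means these few. Any claim that something is new, unique, unknown or untested is made for them only; others in the source may bear on it.

Compound 1, `C=CC(=O)Nc1ccnc(Sc2c(OC)nc(N3CCN(C)CC3)nc2OC)n1`: 1200 nM
Compound 2, `C=CC(=O)Nc1cc(N)nc(Sc2c(OCC)nc(N3CCCCC3)nc2OCC)n1`: 7000 nM

In a functional assay on SK-BR-3 cells (Homo sapiens) for inhibition, read by resazurin assay, with a stated time of 72 h (a lower number here means a stronger inhibitor, a higher number a weaker inhibitor), compound 2 holds the highest of the two numbers; compound 1 sits lower, and that gap lies beyond the scatter. These two compounds differ in several places, so no single step can be read from them. Compound 3 `C=CC(=O)Nc1cc(N)nc(Sc2c(OCC)nc(N3CCN(C)CC3)nc2OCC)n1` carries 4-methylpiperazin-1-yl in place of piperidin-1-yl on an aromatic carbon. Compound 1 also bears the 4-methylpiperazin-1-yl group, but with other differences as well, so the change is not isolated. The step of a 2.0-fold lower number from compound 2 to compound 3 (0.30 log units; within the scatter) is expected to be a modest move downward. Compound 3 is estimated at 3500 nM, between 1200 nM and 10000 nM.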

Compound 3, half-maximal inhibitory concentration: 1100 nM
For compound 3 the middle estimate is 3.2-fold (0.50 log units) above the measured one; the measured number lies below the stated range.
By their numbers in this assay, from the lowest: compounds 3 and 1 (each within the scatter of the next); then compound 2.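

In this assay the aromatic carbon between two ring nitrogen atoms proves responsive to the group it carries: 4-methylpiperazin-1-yl in place of piperidin-1-yl gives a 6.4-fold lower number from compound 2 to compound 3 (0.80 log units; beyond the scatter) as an isolated step. Compounds 1 and 2 could not show such a step. The entering group differs from the leaving one by a second ring nitrogen and a methyl group, but no measurement here ties the step to either feature. From the compounds shown here alone, whether a morpholine or an open-chain amine at this position would match compound 3 remains open.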